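The compounds below may be only part of what the source reports. "The series", "measured", "known", "first", "only" and "open" are said of these compounds alone.

In an ADME assay (liver) for metabolic stability, with Liver microsome (Homo sapiens) as the target, read by LC-MS, using microsomes and NADPH, with a stated time of 5 min, at 37 degrees C (a higher number here means faster removal of the compound, a lower number slower removal), compound 1 `CCn1c([C@@H](C)NS(=O)(=O)c2ccc(Cl)cc2)nc2ccc(OC)cc21` reports only a limit, > 100 mL.min-1.g-1. Compound 2 `CCn1c([C@@H](C)NS(=O)(=O)c2ccc(Cl)cc2)nc2ccc(CO)cc21` gives 84 mL.min-1.g-1, which amounts to an at least 1.1-fold lower number from compound 1 to compound 2 (0.07 log units; that floor lies within the scatter). Compound 3 `CCn1c([C@@H](C)NS(=O)(=O)c2ccc(C#N)cc2)nc2ccc(C(F)(F)F)cc21`, at 34 mL.min-1.g-1, holds the lower of the two actual numbers, a gap from compound 2 that lies beyond the scatter. Compound 4 `CCCn1cc(S(=O)(=O)N[C@H](C)c2nc3ccc(C(F)(F)F)cc3n2CC)c(C)n1` differs from compound 3 by a group of 9 heavy atoms (7 carbon, 2 nitrogen; one five-membered aromatic ring with 2 hetero atoms) in place of a group of 8 heavy atoms (7 carbon, 1 nitrogen; one six-membered aromatic ring of carbon only), on a sulfonyl sulfur. For the measured compounds named here, the only measured step concerns hydroxymethyl in place of methoxy on an aromatic carbon, so no measured step covers the change on the sulfonyl sulfur. With compound 3 at 34 mL.min-1.g-1 and compound 2 at 84 mL.min-1.g-1, a modest upward move is the likelier outcome. The expected step is a 1.6-fold higher number from compound 3 to compound 4 (0.21 log units; within the scatter). Compound 4 is estimated at 55 mL.min-1.g-1, within an expected range from 25 mL.min-1.g-1 to 100 mL.min-1.g-1.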

Compound 4, intrinsic clearance in microsomes: > 100 mL.min-1.g-1
Compound 4 gave a limit, no number; the forecaster's own chance of this, stated with the estimate: 15%; at least 1.8-fold (0.25 log units) between middle value and limit.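

In this assay, replacing the 4-cyanophenyl on the sulfonyl sulfur with the five-membered aromatic ring gives an at least 2.9-fold higher number from compound 3 to compound 4 (0.46 log units; beyond the scatter) in a single change. For the compounds shown here, no earlier step touched this place, so this is the first sign that the group on the sulfonyl sulfur can shift the number beyond the scatter. That step is only a floor, since compound 4 reports a limit and not a number: the limit of > 100 mL.min-1.g-1 in this assay, at which 2 of the 4 values shown sit.

Going by these compounds, how far the number actually rises remains open. On these data alone, it is also open whether a five-membered ring lacking the propyl chain, or a phenyl ring carrying an amine or a carboxylic acid, would read nearer compound 3.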